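The source may report more compounds than this note shows. Statements on the series, on what has been measured and on what is new or still open speak of the compounds shown alone.

Compound 1 `CCOC(=O)n1nc(N)c(/N=N/c2ccc(O)cc2)c1N`: > 100000 nM (a limit)
Compound 2 `Nc1n[nH]c(N)c1/N=N/c1ccc(O)cc1`: 62000 nM
Compound 3 `Nc1nn(C(=O)c2cccs2)c(N)c1/N=N/c1ccc(O)cc1`: > 25000 nM (a limit)

All three results come from a functional assay on MCF7 cells (Homo sapiens) for cytotoxicity, read by fluorescence, with a stated time of 72 h; a higher number here means a weaker inhibitor, a lower number a stronger inhibitor. Compound 3 gives only a limit, > 25000 nM, and not a number.

Compound 4 `Cn1nc(N)c(/N=N/c2ccc(O)cc2)c1N` carries methyl in place of (thiophen-2-yl)carbonyl on an aromatic nitrogen. Three measured steps change this same nitrogen substituent or the group attached through its carbonyl. The closest is a step that the limit leaves unreadable from compound 2 to compound 3, and a step that the two limits leave unreadable from compound 1 to compound 3 is no more informative. The remaining one, an at least 1.6-fold lower number from compound 1 to compound 2 (0.20 log units; that floor lies within the scatter), offers only a floor within the scatter.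

The expectation therefore rests on compound 2, at 62000 nM, whose hydrogen is the closest match to methyl among the measured compounds. No step beyond the scatter is expected, and the estimated step is a step that the limit leaves unreadable from compound 3 to compound 4. The expected value for compound 4 is 60000 nM, with an estimated range from 20000 nM to 120000 nM.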

Compound 4, half-maximal inhibitory concentration: > 100000 nM
Compound 4: no number, only a limit; the forecaster's own chance of this, stated with the estimate: 40%; middle value at least 1.6-fold (0.22 log units) away from the limit.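

Compound 4 gives > 100000 nM in this assay, which is a limit and not a number. With methyl on this aromatic nitrogen, the result is an at least 1.6-fold higher number from compound 2 to compound 4 (0.20 log units; that floor lies within the scatter), so no step beyond the scatter can be claimed for this swap, and compound 2 remains the only compound shown with an actual number. The steps to compound 4 from compound 1 and from compound 3 cannot be read, and a second nitrogen substituent now ends at the same ceiling: the limit of > 100000 nM in this assay, at which 2 of the 4 values shown sit.

From the compounds shown here alone, what a longer chain such as propyl, or a chain ending in an amine, would do on this nitrogen remains open. The true values of compound 1 and compound 4 are also unknown, so these two cannot be ranked against each other.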